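Methoxycarbonyl in place of methyl: expected toxicity

The source may report more compounds than this note shows. Statements on the series, on what has been measured and on what is new or still open speak of the compounds shown alone.

Compound 1 `Cc1ccc(NC(=O)CSc2snnc2-c2ccc(F)cc2F)c(Br)c1` — in an ADME assay on MT4 cells (Homo sapiens) for cytotoxicity (on this read-out lower numbers stand for higher toxicity in this test and higher numbers for lower toxicity in this test), a limit of > 273000 nM was reached, not a number.
Compound 2 `COc1ccc(-c2nnsc2SCC(=O)Nc2ccc(C)cc2Br)cc1` — in this assay compound 2 gives 249000 nM.

Both compounds share one core and differ only in the aryl group carried by that core. On this read-out compound 2 holds the only number shown, while the other value is a limit (the limit of > 273000 nM in this assay, at which 1 of the 2 values shown sits). The step of an at least 1.0-fold lower number from compound 1 to compound 2 (0.03 log units; that floor lies within the scatter) stays within the scatter, so the two compounds look alike in this test.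

Compound 3 `COC(=O)c1ccc(NC(=O)CSc2snnc2-c2ccc(OC)cc2)c(Br)c1` has not been measured yet. It differs from compound 2 by methoxycarbonyl in place of methyl on an aromatic carbon. For the measured compounds named here, no measured step touches this part of the molecule, so none bears directly on the change; the single step measured, at a different place, stayed within the scatter. In this assay compound 3 is therefore expected to show no step beyond the scatter, a 1.2-fold lower number from compound 2 to compound 3 (0.10 log units; within the scatter). The estimate for compound 3 is 200000 nM, with a range from 70000 nM to 400000 nM.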

Compound 3, half-maximal cytotoxic concentration: 195000 nM
The estimate for compound 3 lay 1.0-fold (0.01 log units) above the measured number, within the range that was stated.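

For the compounds shown here, until now only the aryl group on the shared core had changed, so this is the first look at the aromatic carbon para to a large group and meta to a bromo group, and the change there gives a 1.3-fold lower number from compound 2 to compound 3 (0.11 log units; within the scatter). Methoxycarbonyl, with 4 heavy atoms and 2 hydrogen-bond acceptors, takes the place of methyl, with 1 heavy atom and 0 hydrogen-bond acceptors, and compound 2 and compound 3 still look alike in this assay. Nothing shown gives a reason for this outcome.

On these data alone, whether an amine, a carboxylic acid or a longer chain on this carbon would also leave the number within the scatter remains open. A single change at this position shows how methoxycarbonyl behaves here, but it does not establish a trend across other groups.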